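The compounds below may be only part of what the source reports. "The series", "measured", "known", "first", "only" and "open" are said of these compounds alone.

Compound 3 `CS(=O)(=O)c1cc(C(=O)N=C(N)N)ccc1-n1cccn1` is the weakest of the three measured compounds in a functional assay for inhibition of sodium/hydrogen exchanger (Oryctolagus cuniculus) (on this read-out higher numbers stand for weaker inhibition and lower numbers for stronger inhibition), where compound 3 gives 160 nM. Compound 1 `Cc1cc(Sc2cccc(Cl)c2)c(S(C)(=O)=O)cc1C(=O)N=C(N)N` gives 37 nM in this assay, and compound 2 `Cc1cc(Oc2ccccc2Cl)c(S(C)(=O)=O)cc1C(=O)N=C(N)N` gives 14 nM, so both stand clearly below compound 3.

Compound 4 `Cc1cc(-n2cccn2)c(S(C)(=O)=O)cc1C(=O)N=C(N)N` differs from compound 3 by a single change: methyl in place of hydrogen on an aromatic carbon. Within the data shown here, no measured step concerns this change. Among the measured compounds shown here, the only measured step, a 2.6-fold lower number from compound 1 to compound 2 (0.42 log units; beyond the scatter), concerns a different part of the molecule, the group attached through sulfur or oxygen, and says nothing about a methyl added to the shared core. Compounds 1 and 2 both carry this methyl and both give lower numbers than compound 3, but they also carry a different group in place of the 1H-pyrazol-1-yl group, so their values cannot be read as the effect of the methyl alone.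

With no direct comparison, a cautious expectation is a modest move toward a lower number, a 2.0-fold lower number from compound 3 to compound 4 (0.30 log units; within the scatter), leaning on the lower values of compound 1 and compound 2. Compound 4 is therefore expected to give about 80 nM in this assay, with a likely range from 25 nM to 250 nM.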

Compound 4, half-maximal inhibitory concentration: 25 nM
Beside the measured number, compound 4's estimate is 3.2-fold (0.51 log units) above it, within the range that was stated.
By their numbers in this assay, from the lowest: compounds 2, 4 and 1 (each within the scatter of the next, the first and the last beyond it); then compound 3.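

In this assay, among these compounds, this is the first direct reading of the methyl on the aromatic carbon para to a methylsulfonyl group, and the change counts for a good deal: the pair shows a 6.4-fold lower number from compound 3 to compound 4 (0.81 log units; beyond the scatter) from this single added carbon. With the methyl in place, the 1H-pyrazol-1-yl group cannot be told apart from either earlier group, since a 1.8-fold higher number from compound 2 to compound 4 (0.25 log units; within the scatter) and a 1.5-fold lower number from compound 1 to compound 4 (0.17 log units; within the scatter) both lie within the scatter, so the lower numbers of compound 1 and compound 2 need not depend on their 2-chlorophenoxy or (3-chlorophenyl)sulfanyl groups. Nothing available explains why one methyl moves the number this far.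

It remains open whether the methyl would bring a similar step on the cores of compound 1 and compound 2, as the compounds shown offer a pair for this change only with the 1H-pyrazol-1-yl group. From the compounds shown here alone, it is equally open how an ethyl, a methoxy or an amine on this same carbon would compare with the methyl.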